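The compounds below may be only part of what the source reports. "The series", "measured", "known", "first", "only" and "open" are said of these compounds alone.

Compound 1 `Cc1nc(S(C)(=O)=O)ccc1Oc1ncnc(OC2CCN(C(=O)OC(C)C)CC2)c1F` gives 21 nM in a functional assay on isolated protein for inhibition of Glucose-dependent insulinotropic receptor (Homo sapiens), read by HTRF and cAMP accumulation; a higher number here means that more compound is needed for the effect, a lower number that less compound is needed. Compound 2 `Cc1nc(S(C)(=O)=O)ccc1Oc1ncnc(OC2CCN(C(=O)OC3CCC3)CC2)c1F` gives 13.6 nM in this assay. Compound 3 `Cc1nc(S(C)(=O)=O)ccc1Oc1ncnc(OC2CCN(C(=O)OC(C)(C)CF)CC2)c1F` gives 19.9 nM in this assay.

Compound 2 carries the lowest of the three numbers, but the gaps are slight: a 1.5-fold lower number from compound 1 to compound 2 (0.19 log units; within the scatter) and a 1.5-fold higher number from compound 2 to compound 3 (0.17 log units; within the scatter) both stay within the scatter. Compound 4 `Cc1nc(S(C)(=O)=O)ccc1Oc1ncnc(OC2CCN(C(=O)O[C@H](C)C(F)(F)F)CC2)c1F` differs from compound 2 by 1-(trifluoromethyl)ethyl in place of cyclobutyl on an oxygen next to a carbonyl group. The step that bears most directly on this change, which likewise swaps cyclobutyl for a fluorine-bearing group on the oxygen next to a carbonyl group, is a 1.5-fold higher number from compound 2 to compound 3 (0.17 log units; within the scatter), and the isopropyl comparison a 1.5-fold lower number from compound 1 to compound 2 (0.19 log units; within the scatter) is equally small. Nothing among the three measured compounds points to a step beyond the scatter. Compound 4 is therefore expected to give about 18 nM in this assay, between 9 nM and 36 nM, an expected step of a 1.3-fold higher number from compound 2 to compound 4 (0.12 log units; within the scatter) that should remain within the scatter.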

Compound 4, half-maximal effective concentration: 9.2 nM
For compound 4 the middle estimate is 2.0-fold (0.29 log units) above the measured one, within the range that was stated.
By their numbers in this assay, from the lowest: compounds 4, 2, 3 and 1 (each within the scatter of the next, the first and the last beyond it).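

Going by these compounds alone, on the oxygen next to a carbonyl group, 1-(trifluoromethyl)ethyl gives the first steps beyond the scatter, with a 2.2-fold lower number from compound 3 to compound 4 (0.34 log units; beyond the scatter) and a 2.3-fold lower number from compound 1 to compound 4 (0.36 log units; beyond the scatter) in this assay, although both are modest. Against cyclobutyl the change stays small, with a 1.5-fold lower number from compound 2 to compound 4 (0.17 log units; within the scatter), so this position accepts a group without a ring as well as one with it. Nothing measured here explains these steps.

Going by these compounds, what the defined stereocentre of compound 4 contributes remains open. So does how a longer chain or a phenyl group would read at this oxygen.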